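Replacing the phenol arm of compound 3 with trimethoxyphenyl

A few compounds are considered here, and "the series" means these few. Any claim that something is new, unique, unknown or untested is made for them only; others in the source may bear on it.

Of the compounds shown here, three built on one shared core have been tested in a physicochemical assay, with a stated time of 30 min; on this read-out higher numbers stand for weaker inhibition and lower numbers for stronger inhibition. Compound 1 `COc1cc(COc2ccc(C(=O)N/N=C/c3cc(Br)cc(Cl)c3O)cc2)cc(OC)c1OC` is reported only at the limit of this assay, > 100 ug/mL, which is a limit and not a number (the limit of > 100 ug/mL in this assay, at which 1 of the 3 values shown sits). Compound 2 `COc1cc(/C=N/NC(=O)c2ccc(OCc3cc(OC)c(OC)c(OC)c3)cc2)cc(OC)c1O` gives 75 ug/mL in this assay. Compound 3 `CCOc1cc(/C=N/NC(=O)c2ccc(OCc3cc(OC)c(OC)c(OC)c3)cc2)ccc1O` gives 106 ug/mL in this assay, the highest of the two numbers shown, and its nearest neighbour is compound 2: a 1.4-fold higher number from compound 2 to compound 3 (0.15 log units; within the scatter).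

Compound 4 `COc1cc(COc2ccc(C(=O)N/N=C/c3ccc(OC)c(OC)c3OC)cc2)cc(OC)c1OC` differs from compound 3 at the same place that all the earlier changes touched: 2,3,4-trimethoxyphenyl in place of 3-ethoxy-4-hydroxyphenyl on a carbon with a double bond to nitrogen. Among the measured compounds shown here, three measured steps bear on this place. an at least 1.3-fold lower number from compound 1 to compound 2 (0.12 log units; that floor lies within the scatter). a step that the limit leaves unreadable from compound 1 to compound 3. a 1.4-fold higher number from compound 2 to compound 3 (0.15 log units; within the scatter). For the measured compounds named here, every readable change of the group on the carbon with a double bond to nitrogen has stayed within the scatter, and no measured step covers a group with no hydrogen-bond donor. For compound 4 the expected step is therefore one that stays within the scatter, a 1.1-fold higher number from compound 3 to compound 4 (0.05 log units; within the scatter), with the caveat that a number near the limit of this assay may again be reported only as a limit. Compound 4 is estimated at 120 ug/mL, within a range from 60 ug/mL to 250 ug/mL.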

Compound 4, half-maximal inhibitory concentration: > 100 ug/mL
Compound 4 was reported as a limit (the forecaster's own chance of this, stated with the estimate: 40%); the middle value does not contradict the limit.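

Among the compounds shown, only compound 4 puts a group with 0 hydrogen-bond donors on the carbon with a double bond to nitrogen: 2,3,4-trimethoxyphenyl in place of 3-ethoxy-4-hydroxyphenyl. In this assay compound 4 is reported only as a limit and not as a number, so its steps from compound 3 and from compound 1 cannot be read. Among the compounds shown here, the one readable step is an at least 1.3-fold higher number from compound 2 to compound 4 (0.12 log units; that floor lies within the scatter) and it gives no sign of stronger inhibition with this group, while the limit now holds more of the compounds: the limit of > 100 ug/mL in this assay, at which 2 of the 4 values shown sit.

The compounds shown leave open how far the number for compound 4 really lies from those of compound 2 and compound 3, and so whether the hydroxyl on this ring matters at all on this read-out. Also open, on these data alone, is how the same core would read with a quite different group at this position, such as an amine or a carboxylic acid, in place of the substituted phenyl groups seen so far.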